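Adding a Third Methoxy Group to Compound 3

The compounds below may be only part of what the source reports. "The series", "measured", "known", "first", "only" and "open" are said of these compounds alone.

Three compounds have been measured in a functional assay on MDA-MB-231 cells (Homo sapiens) for antiproliferative activity, with a stated time of 48 h; on this read-out higher numbers stand for lower toxicity in this test and lower numbers for higher toxicity in this test:
compound 1, `Cc1cc(O)c(C2=NN(c3ccc(S(N)(=O)=O)cc3)C(c3ccccc3Cl)C2)cc1Cl`, gives 9520 nM
compound 2, `Cc1cc(O)c(C2=NN(c3ccc(S(N)(=O)=O)cc3)C(/C=C/c3ccccc3)C2)cc1Cl`, gives 40800 nM
compound 3, `COc1ccc(C2CC(c3cc(Cl)c(C)cc3O)=NN2c2ccc(S(N)(=O)=O)cc2)cc1OC`, gives 40400 nM

All three share the same core and differ only in the group attached to a saturated ring carbon. Compound 3 sits second highest of the three numbers, within the scatter of compound 2 and well apart from compound 1: a 4.2-fold higher number from compound 1 to compound 3 (0.63 log units; beyond the scatter), and similarly a 4.3-fold higher number from compound 1 to compound 2 (0.63 log units; beyond the scatter). Between the two larger substituents there is no real gap, a 1.0-fold lower number from compound 2 to compound 3 (0.00 log units; within the scatter).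

Compound 4, `COc1ccc(C2CC(c3cc(Cl)c(C)cc3O)=NN2c2ccc(S(N)(=O)=O)cc2)c(OC)c1OC`, differs from compound 3 by a single change: methoxy in place of hydrogen on an aromatic carbon. Among the compounds with values here, none of the measured steps involves adding a group to an aryl ring already present; they only swap one whole aryl group for another. Within the data shown here, the only guidance is that compound 2 and compound 3, two rather different groups, gave the same number in this assay, which suggests this position tolerates variation without large shifts. A step of no more than the usual scatter is therefore expected in this assay, a 1.2-fold lower number from compound 3 to compound 4 (0.06 log units; within the scatter). Compound 4 is expected to give about 35000 nM, with a range from 14000 nM to 90000 nM.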

Compound 4, concentration lethal to 50% of the cells: 16300 nM
The estimate for compound 4 lay 2.1-fold (0.33 log units) above the measured number; low and high end bracket the measured number.
By their numbers in this assay, from the lowest: compounds 1 and 4 (each within the scatter of the next); then compounds 3 and 2 (each within the scatter of the next).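

In this assay, adding one methoxy to the aryl ring, on an aromatic carbon ortho to a large group and ortho to a methoxy group, gives a 2.5-fold lower number from compound 3 to compound 4 (0.39 log units; beyond the scatter) and so moves the number beyond the scatter, which shows that a small edit to this ring can matter even though the very different groups of compound 2 and compound 3 gave matching numbers. Within the data shown here, the 2,3,4-trimethoxyphenyl group also separates from 2-phenylethenyl, with a 2.5-fold lower number from compound 2 to compound 4 (0.40 log units; beyond the scatter), while its gap to 2-chlorophenyl stays small, with a 1.7-fold higher number from compound 1 to compound 4 (0.23 log units; within the scatter), so the position is less indifferent to its substituent than the earlier compounds suggested. Nothing available explains why this added methoxy shifts the number.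

On these data alone, it remains open whether a hydroxy, an ethoxy or a chlorine on that same aromatic carbon would give a step of similar size, which would show how much depends on methoxy itself. As far as these compounds go, it is also open whether a third methoxy on a different carbon of the ring, as in a 3,4,5-trimethoxyphenyl group, would give the same shift, or whether this particular carbon is what counts.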